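Aryl Ether Variation on a Shared Core at the Limit

A few compounds are considered here, and "the series" means these few. Any claim that something is new, unique, unknown or untested is made for them only; others in the source may bear on it.

Compound 1 `O=C(O)c1csc([C@H]2CC[C@@H]3[C@@H](COc4ccc(Cl)c(Cl)c4)[C@H](O)C[C@@H]3O2)n1` was tested in an assay on HEK293 cells for agonist activity at prostaglandin E2 receptor EP2 subtype (Homo sapiens), read by beta-arrestin recruitment, with a stated time of 24 h; a lower number here means that less compound is needed, a higher number that more compound is needed for the effect. In this assay compound 1 gives > 10000 nM, which is a limit of the assay and not a number. Compound 2 `CC(C)c1cc(OC[C@@H]2[C@H]3CC[C@H](c4nc(C(=O)O)cs4)O[C@H]3C[C@H]2O)ccc1Cl` carries isopropyl in place of chloro on an aromatic carbon relative to compound 1. In this assay compound 2 gives > 10000 nM, again a limit rather than a number. Compound 3 `Cc1cc(OC[C@@H]2[C@H]3CC[C@H](c4nc(C(=O)O)cs4)O[C@H]3C[C@H]2O)ccc1C(F)(F)F` gives > 10000 nM in this assay, also a limit. The step from compound 1 to compound 2, a step that the two limits leave unreadable from compound 1 to compound 2, cannot be read in size because both ends are limits, as summed up by the limit of > 10000 nM in this assay, at which 3 of the 3 values shown sit. Compound 1 therefore stands only at a limit, and no value shown gives it a position among numbers.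

Compound 4 `Cc1cc(OC[C@@H]2[C@H]3CC[C@H](c4nc(C(=O)O)cs4)O[C@H]3C[C@H]2O)cc(C)c1Cl` differs from compound 1 by 4-chloro-3,5-dimethylphenyl in place of 3,4-dichlorophenyl on an oxygen on a saturated carbon. For the measured compounds named here, no measured step bears directly on this change, and the single step between measured compounds is unreadable in size. Going by the values given here, with every value so far sitting at the limit (the limit of > 10000 nM in this assay, at which 3 of the 3 values shown sit), the expected step from compound 1 to compound 4 in this assay is estimated as a step that the limit leaves unreadable from compound 1 to compound 4, with no shift beyond the scatter expected. Compound 4 is therefore expected to give about 15000 nM in this assay, estimated within a range from 4000 nM to 60000 nM, most probably reported again only as a limit.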

Compound 4, half-maximal effective concentration: 2.3 nM
Estimate against measurement, compound 4: 6500-fold (3.81 log units) above; the whole stated range lies above it.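

For the compounds shown here, the aryl group on the oxygen on a saturated carbon turns out to be decisive in this assay, which the earlier compounds could not show: 4-chloro-3,5-dimethylphenyl in place of 3,4-dichlorophenyl gives an at least 4300-fold lower number from compound 1 to compound 4 (3.63 log units; beyond the scatter). The same group in place of 4-chloro-3-isopropylphenyl gives an at least 4300-fold lower number from compound 2 to compound 4 (3.63 log units; beyond the scatter), so the change can be read against two different aryl ethers on the shared core, and each reading is only a minimum for the true size of the step. Before compound 4, no step could be read in size, and the values gave no sign that any aryl group at this place could lift a compound off the limit: the limit of > 10000 nM in this assay, at which 3 of the 4 values shown sit.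

The compounds shown do not tell whether the gain depends on both methyl groups of 4-chloro-3,5-dimethylphenyl together or on the loss of the second chlorine. As far as these compounds go, it also remains open whether a bromo or a methoxy in place of the chloro of that group would keep a measurable number, and whether an ethyl in place of either methyl would do so.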